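The source may report more compounds than this note shows. Statements on the series, on what has been measured and on what is new or still open speak of the compounds shown alone.

Measured so far in a functional assay on HL-60 cells (Homo sapiens) for antiproliferative activity, read by MTT assay, with a stated time of 72 h; on this read-out higher numbers stand for weaker inhibition and lower numbers for stronger inhibition:
compound 1 `NC1=NC2(CCSCC2)N(OCCCOc2ccc(Cl)c(Cl)c2)C(N)=N1`: 140 nM
compound 2 `NC1=NC2(CCOCC2)N(OCCCOc2cc(Cl)c(Cl)cc2Cl)C(N)=N1`: 2360 nM

Compound 1 has the lower of these two numbers, and compound 2 lies well above it, beyond the usual scatter of repeated measurements. The next compound to be tested is compound 3 `NC1=NC2(CCSCC2)N(OCCCOc2ccccc2Br)C(N)=N1`. It keeps the rest of compound 1 but carries 2-bromophenyl in place of 3,4-dichlorophenyl on an oxygen on a saturated carbon. Among the compounds with values here, no measured pair shows what such a swap does, so any expectation here is loose. Compound 1, at 140 nM, holds the lower of just two values, so a new group seems more likely to raise the number than to lower it. In this assay the expected change is a 2.9-fold higher number from compound 1 to compound 3 (0.46 log units; beyond the scatter), a weakening beyond the scatter but not a large one. For compound 3 the estimated value is 400 nM, with an expected range of 120 nM to 1400 nM.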

Compound 3, half-maximal inhibitory concentration: 180 nM
Compound 3: the middle estimate sits 2.2-fold (0.35 log units) above what was measured, within the range that was stated.
By their numbers in this assay, from the lowest: compounds 1 and 3 (each within the scatter of the next); then compound 2.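

In this assay, putting 2-bromophenyl in place of 3,4-dichlorophenyl on an oxygen on a saturated carbon gives a 1.3-fold higher number from compound 1 to compound 3 (0.11 log units; within the scatter). Within the data shown here, this is the first direct reading of a swap at this position: with the rest of the molecule held the same, a ring carrying one bromine and a ring carrying two chlorines cannot be told apart in this test. Nothing measured here explains why these two groups read alike.

The compounds shown leave open whether this ring needs a halogen at all, which a plain phenyl or a 4-methoxyphenyl at the same position could test. They also leave open what a longer chain carrying the ring would do on the core of compound 1.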